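From compound 3 to compound 4: oxan-4-yl for 2-bromophenyl

The source may hold more compounds than are shown below. What is called first, only, known or untested is meant among the compounds shown, and "the series" means these compounds.

Compound 1 `COc1ccc(-c2cnc(NC(=O)c3cccc(C#N)c3)n2C)cc1`: > 100000 nM
Compound 2 `COc1ccc(-c2cnc(NC(=O)c3ccc(F)cc3)n2C)cc1`: >= 50000 nM
Compound 3 `COc1ccc(-c2cnc(NC(=O)c3ccccc3Br)n2C)cc1`: > 100000 nM

All three results come from a toxicity assay on THP-1 cells (Homo sapiens) for inhibition (on this read-out lower numbers stand for higher toxicity in this test and higher numbers for lower toxicity in this test), and each is a limit rather than a number. Compound 3 stands with the other two, its result being the limit > 100000 nM.

Compound 4 `COc1ccc(-c2cnc(NC(=O)C3CCOCC3)n2C)cc1` differs from compound 3 as follows: oxan-4-yl in place of 2-bromophenyl on a carbonyl carbon. In words, oxan-4-yl stands in place of 2-bromophenyl on a carbonyl carbon.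

Three measured steps change the group on that same carbonyl carbon: a step that the two limits leave unreadable from compound 1 to compound 2, a step that the two limits leave unreadable from compound 1 to compound 3 and a step that the two limits leave unreadable from compound 2 to compound 3. Their limits leave the size of each unreadable, and none of them brings in a non-aromatic ring. They therefore offer no measured size to carry over, and no step beyond the scatter is expected in this assay. The expected change is a number no higher from compound 3 to compound 4 (the limit leaves the size open). Compound 4 is expected to be reported as a limit again, with an estimated value of 100000 nM and an expected range from 50000 nM to 200000 nM.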

Compound 4, half-maximal cytotoxic concentration: > 100000 nM
Compound 4 gave a limit, no number; the forecaster's own chance of this, stated with the estimate: 85%; the middle value sits exactly at the limit.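

In this assay compound 4 gives > 100000 nM, a limit and not a number. The steps to it from compound 1, compound 2 and compound 3 cannot be read. The compounds shown leave open what number any of the four would give, and whether the group on the carbonyl carbon changes the result at all.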